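The compounds below may be only part of what the source reports. "The series", "measured", "known", "first", "only" and "open" are said of these compounds alone.

Working notes on the series.

The shared core carries a nitro group on a five-membered ring with a hydroxypropyl chain, and a double-bonded two-carbon chain links it to a substituted phenyl ring. Compound 1 `CC(O)Cn1c([N+](=O)[O-])cnc1/C=C/c1ccc(Br)cc1` bears a 4-bromophenyl on that chain. In an ADME assay on cells (Macrophage, Homo sapiens) for cytotoxicity, read by MTT assay, with a stated time of 24 h (a higher number here means that more compound is tolerated, a lower number that less compound is tolerated), compound 1 gives 550 nM. Compound 2 `CC(O)Cn1c([N+](=O)[O-])cnc1/C=C/c1ccc([N+](=O)[O-])cc1` differs by nitro in place of bromo on an aromatic carbon; in this assay compound 2 gives 410 nM, and the step of a 1.3-fold lower number from compound 1 to compound 2 (0.13 log units; within the scatter). Compound 3 `CC(O)Cn1c([N+](=O)[O-])cnc1/C=C/c1cccc(Br)c1` differs from compound 1 by 3-bromophenyl in place of 4-bromophenyl on a double-bonded chain carbon bound to a double-bonded chain carbon; in this assay compound 3 gives 620 nM, and the step of a 1.1-fold higher number from compound 1 to compound 3 (0.05 log units; within the scatter). The three values lie within the usual scatter of one another, so no ordering among them is claimed.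

Compound 4 `CC(O)Cn1c([N+](=O)[O-])cnc1/C=C/c1cccc([N+](=O)[O-])c1` is not yet measured. It differs from compound 3 by nitro in place of bromo on an aromatic carbon. This is the same kind of change as that from compound 1 to compound 2, made on a different core: there the place was para to a large group, here it is meta to a large group. For the measured compounds named here, the one measured instance of this change, from compound 1 to compound 2, moved the number only within the scatter, so a step of similar size is expected here, a 1.3-fold lower number from compound 3 to compound 4 (0.11 log units; within the scatter), resting on the single earlier step of a 1.3-fold lower number from compound 1 to compound 2 (0.13 log units; within the scatter) applied to the value of compound 3, 620 nM. For compound 4 in this assay the estimate is 480 nM, with a likely range from 280 nM to 850 nM.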

Compound 4, half-maximal cytotoxic concentration: 430 nM
The estimate for compound 4 lay 1.1-fold (0.05 log units) above the measured number; low and high end bracket the measured number.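

In this assay, nitro in place of bromo on an aromatic carbon gives a 1.4-fold lower number from compound 3 to compound 4 (0.16 log units; within the scatter), and the replacement behaves alike on the two cores: the same change on two cores in this assay, a 1.3-fold lower number (0.13 log units; within the scatter) from compound 1 to compound 2 and a 1.4-fold lower number (0.16 log units; within the scatter) from compound 3 to compound 4, 1.1-fold (0.03 log units) apart, within the scatter of two such steps Both steps stay inside the scatter, so what carries from the core of compound 1 to the core of compound 3 is only the absence of a readable effect on the number, not an established direction or size. Two such pairs, all within a narrow band of values in a single assay, do not make a rule for other cores in the series, and they give no reason why the two steps agree.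

What the compounds shown leave open is whether any substituent on the phenyl ring shifts the number beyond the scatter, since only bromo and nitro appear there, and an amine or a carboxylic acid in the same places would test this more sharply. Also open, on these data alone, is how the number responds to edits elsewhere on the shared core, such as a longer chain in place of the hydroxypropyl chain, or to the removal of the nitro group on the five-membered ring.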